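Phenyl to pyridin-4-yl at the limit of the assay

The compounds below may be only part of what the source reports. "The series", "measured", "known", "first", "only" and "open" are said of these compounds alone.

In an ADME assay on RAW264.7 cells (Mus musculus) for cytotoxicity, read by MTT assay (on this read-out lower numbers stand for stronger inhibition and higher numbers for weaker inhibition), compound 1 `COc1cc(/C=C/c2nc(NC3CC3)c3sccc3n2)cc(OC)c1OC` gives > 50000 nM as a limit, not a number. Compound 2 `COc1cc(/C=C/c2nc(NCc3ccccc3)c3sccc3n2)cc(OC)c1OC` gives > 50000 nM as a limit too, so it stands at the limit of > 50000 nM in this assay, at which 2 of the 2 values shown sit, with no number of its own. Among the measured compounds shown here, the only measured step is a step that the two limits leave unreadable from compound 1 to compound 2 and offers no size to carry over. In compound 3 `COc1cc(/C=C/c2nc(NCc3ccncc3)c3sccc3n2)cc(OC)c1OC` pyridin-4-yl replaces phenyl pyridin-4-yl in place of phenyl on a saturated chain carbon bound to a nitrogen on an aromatic ring on a saturated chain carbon bound to a nitrogen on an aromatic ring. From compound 2 at > 50000 nM as a limit, no step beyond the scatter is expected in this assay in either direction. The estimated step is a number no higher from compound 2 to compound 3 (the limit leaves the size open) at most a small one. Compound 3 is expected at 50000 nM within an estimated range of 25000 nM to 100000 nM in this assay.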

Compound 3, half-maximal inhibitory concentration: > 50000 nM
Compound 3 was reported as a limit; the forecaster's own chance of this, stated with the estimate: 80%; the middle value lies on the limit itself.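

No step can be read among compound 1, compound 2 and compound 3, because all three stand at the same limit: the limit of > 50000 nM in this assay, at which 3 of the 3 values shown sit. Left open is how they would compare in this assay if each had a number of its own.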